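This account rests on a few compounds, and the source may have more. Where it says the series, first, only, none or still open, it means among the compounds named here.

Of the compounds shown here, three built on one shared core have been tested in a functional assay on HeLa cells (Homo sapiens) for cytotoxicity, read by CCK-8 assay, with a stated time of 24 h; on this read-out lower numbers stand for stronger inhibition and higher numbers for weaker inhibition. Compound 1, `C/C(=C\c1cc(-c2ccc(F)cc2)co1)C(N)=O`, gives 11800 nM in this assay. Compound 2, `C/C(=C\c1cc(-c2cccnc2)co1)C(N)=O`, reaches only the limit of the assay, > 50000 nM, so no number is known for it. Compound 3, `C/C(=C\c1cc(-c2ccc(C)nc2)co1)C(N)=O`, likewise sits at the limit of the assay, > 50000 nM. The single-place step that the two limits leave unreadable from compound 2 to compound 3 therefore cannot be sized, because the limit of > 50000 nM in this assay, at which 2 of the 3 values shown sit, hides any difference between the two. On the numbers shown, compound 3 thus stands at the limit, where compound 2 also sits, while compound 1 is the only one of the three with a measured number.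

Compound 4, `C/C(=C\c1cc(-c2ccc(F)nc2)co1)C(N)=O`, is the next compound to be measured. It differs from compound 3 in one place: fluoro in place of methyl on an aromatic carbon. Among the compounds with values here, no measured step describes a change from methyl to fluoro, and the only step on the same ring, the one from compound 2 to compound 3, is unreadable. Both compounds carrying this ring sit at the limit, whereas compound 1, which carries fluoro on a different ring, has a number. The step that the limit leaves unreadable from compound 3 to compound 4 is therefore expected to be no larger than the scatter, and the most likely outcome is again a limit. Compound 4 is estimated at 60000 nM, within a range from 20000 nM to 200000 nM.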

Compound 4, half-maximal inhibitory concentration: > 50000 nM
Compound 4: no number, only a limit (the forecaster's own chance of this, stated with the estimate: 75%); the middle value lies beyond the limit too.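

Within the data shown here, no step among compound 2, compound 3 and compound 4 can be read, because all three sit at a limit rather than at a number: the limit of > 50000 nM in this assay, at which 3 of the 4 values shown sit.

The compounds shown leave open how far apart these three really lie in this assay and whether any group on their six-membered aromatic ring with 1 nitrogen would give a measurable number.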